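Replacing the Nitrile with a Methyl Ester: Compound 4

The source may hold more compounds than are shown below. What is called first, only, known or untested is meant among the compounds shown, and "the series" means these compounds.

Compound 1, `N#Cc1ccccc1-c1ccc(CSc2ncnc3ccccc23)cc1`: in an assay on isolated protein for inhibition of phosphodiesterase 7 (Homo sapiens), read by scintillation proximity assay and cAMP accumulation, with a stated time of 1 h (a higher number here means a weaker inhibitor, a lower number a stronger inhibitor), compound 1 gives > 100000 nM, which is a limit of the assay and not a number.
Compound 2, `Cc1nc(SCc2ccc(-c3ccccc3C#N)cc2)c2ccccc2n1`: in this assay compound 2 gives > 100000 nM, again a limit.
Compound 3, `CC(C)c1nc(SCc2ccc(-c3ccccc3C#N)cc2)c2ccccc2n1`: in this assay compound 3 gives > 100000 nM, also a limit.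

Compound 3 therefore stands nowhere in particular on the numbers shown: its value is a limit, and the two other values are limits as well. The three measured steps, a step that the two limits leave unreadable from compound 1 to compound 2, a step that the two limits leave unreadable from compound 1 to compound 3 and a step that the two limits leave unreadable from compound 2 to compound 3, cannot be sized, because the limit of > 100000 nM in this assay, at which 3 of the 3 values shown sit, holds all three values at the same edge of the assay.

Compound 4, `COC(=O)c1ccccc1-c1ccc(CSc2nc(C(C)C)nc3ccccc23)cc1`, differs from compound 3 by methoxycarbonyl in place of cyano on an aromatic carbon. For the measured compounds named here, none of the measured steps touches this part of the molecule; they all concern the substituent on the shared core, and even there they read nothing. So no measured step bears on the change from compound 3 to compound 4, and the expectation can rest only on the fact that every measured compound sits at the limit.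

Compound 4 is expected to give 100000 nM in this assay, within a range from 20000 nM to 500000 nM. The step from compound 3 to compound 4 is thus estimated as a number no higher from compound 3 to compound 4 (the limit leaves the size open), most likely another limit.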

Compound 4, half-maximal inhibitory concentration: > 100000 nM
Compound 4: a limit, no number; the forecaster's own chance of this, stated with the estimate: 65%; the middle value sits exactly at the limit.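

In this assay compound 4 gives > 100000 nM, which is a limit of the assay and not a number. No step can be read from compound 3 to compound 4, because both compounds sit at the same edge of the assay: the limit of > 100000 nM in this assay, at which 4 of the 4 values shown sit.

The compounds shown leave open how strongly any of them inhibits the enzyme, and whether methoxycarbonyl in place of cyano alters that at all.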